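The source may hold more compounds than are shown below. What is called first, only, known or untested is meant among the compounds shown, and "the series" means these compounds.

Compound 1, `CCN(CC)CCCN(C(=O)c1ccc(-c2ccccc2)[nH]1)C(C)C(=O)NC(C)(C)C`, gives 1180 nM in an assay on isolated protein for binding affinity to growth hormone secretagogue receptor type 1 (Homo sapiens); on this read-out lower numbers stand for stronger inhibition and higher numbers for weaker inhibition. Compound 2, `CCN(CC)CCCN(C(=O)c1ccc(-c2ccccc2)[nH]1)C(C(=O)NC1CCCCC1)c1ccc(OC)c(OC)c1`, gives 2630 nM in this assay.

Compound 2 stands at the higher of the two numbers; compound 1 sits lower, a gap beyond the usual scatter. Compound 3, `CCCC(C(=O)NC1CCCCC1)N(CCCN(CC)CC)C(=O)c1ccc(-c2ccccc2)[nH]1`, carries propyl in place of 3,4-dimethoxyphenyl on a saturated chain carbon bound to an amide-type nitrogen and a carbonyl carbon. Going by the values given here, no single-change step between measured compounds sets the size of such a swap. Compound 1, which also bears a short chain at that carbon, gives 1180 nM, so a modest move toward lower numbers is expected, a 1.8-fold lower number from compound 2 to compound 3 (0.24 log units; within the scatter). Compound 3 is therefore estimated at 1500 nM, ranging from 500 nM to 5000 nM.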

Compound 3, inhibition constant: 870 nM
Compound 3: middle estimate off by 1.7-fold (0.24 log units), on the high side; low and high end bracket the measured number.
By their numbers in this assay, from the lowest: compounds 3 and 1 (each within the scatter of the next); then compound 2.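

At the saturated chain carbon bound to an amide-type nitrogen and a carbonyl carbon, binding in this assay does not depend on 3,4-dimethoxyphenyl: with the rest of the molecule unchanged, propyl in its place gives a modest gain (a 3.0-fold lower number from compound 2 to compound 3 (0.48 log units; beyond the scatter)). Going by these compounds alone, this gives the first single-change reading at this position, and it shows that a group with no ring is accepted there. Nothing measured here explains the step.

Whether the ring itself or its two methoxy groups account for the difference stays open. So does how an unsubstituted phenyl, a longer chain or an amine at this carbon would compare with propyl.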